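The source may report more compounds than this note shows. Statements on the series, on what has been measured and on what is new or still open speak of the compounds shown alone.

Measured in a functional assay on HL-60 cells (Homo sapiens) for antiproliferative activity, read by MTT assay, with a stated time of 48 h; on this read-out higher numbers stand for weaker inhibition and lower numbers for stronger inhibition:
- compound 1 `CCCCc1ccc2[nH]c(-c3ccc(OC)cc3)c(/C=N/NC(=O)c3ccc(F)cc3)c2c1`: 164 nM
- compound 2 `CCCCc1ccc2[nH]c(-c3ccc(OC)cc3)c(/C=N/NC(=O)c3ccccc3OC)c2c1`: 142 nM
- compound 3 `CCCCc1ccc2[nH]c(-c3ccc(OC)cc3)c(/C=N/NC(=O)c3cccnc3)c2c1`: 115 nM

Compound 3, at 115 nM, cannot be told apart from the other two, since a 1.4-fold lower number from compound 1 to compound 3 (0.15 log units; within the scatter) and a 1.2-fold lower number from compound 2 to compound 3 (0.09 log units; within the scatter) both lie within the scatter. Compound 4 `CCCCc1ccc2[nH]c(-c3ccc(OC)cc3)c(/C=N/NC(=O)c3ccccn3)c2c1` carries pyridin-2-yl in place of pyridin-3-yl on a carbonyl carbon. The measured exchanges at this same place bear on it, and a 1.2-fold lower number from compound 1 to compound 2 (0.06 log units; within the scatter) also stays within the scatter. No step beyond the scatter is therefore expected in this assay, and the expected step is a 1.1-fold higher number from compound 3 to compound 4 (0.05 log units; within the scatter). For compound 4 the estimate is 130 nM, with an expected range from 70 nM to 240 nM.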

Compound 4, concentration for 90% inhibition: 333 nM
Beside the measured number, compound 4's estimate is 2.6-fold (0.41 log units) below it; the measured number lies above the stated range.
By their numbers in this assay, from the lowest: compounds 3, 2 and 1 (each within the scatter of the next); then compound 4.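

Swapping pyridin-3-yl for pyridin-2-yl on the carbonyl carbon, with the same atoms joined differently, gives a 2.9-fold higher number from compound 3 to compound 4 (0.46 log units; beyond the scatter) in this assay, the first step at this place beyond the scatter. Compound 4 also stands apart from the other two groups, with a 2.3-fold higher number from compound 2 to compound 4 (0.37 log units; beyond the scatter) and a 2.0-fold higher number from compound 1 to compound 4 (0.31 log units; beyond the scatter), so this place does not tolerate every exchange equally, although compounds 1, 2 and 3 remain within the scatter of one another. Nothing available accounts for this difference. The compounds shown leave open how pyridin-4-yl or a carboxylic acid-bearing phenyl would read at this carbonyl carbon.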